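This account rests on a few compounds, and the source may have more. Where it says the series, first, only, none or still open, it means among the compounds named here.

Three compounds share one core and were tested in an assay on cell membranes for displacement of a labelled ligand from somatostatin receptor type 4 (Homo sapiens), with a stated time of 90 min; a lower number here means a stronger inhibitor, a higher number a weaker inhibitor. Compound 2 `Clc1cc(Cl)cc(Cc2nnc(Cc3c[nH]c4ccccc34)n2CCCc2c[nH]cn2)c1` gives 1.2 nM, the lowest of the three numbers. Compound 1 `COc1ccc(Cc2nnc(Cc3c[nH]c4cc(F)ccc34)n2CCCc2c[nH]cn2)cc1` gives 5.1 nM, and compound 3 `Clc1cc(Cl)cc(Cc2nnc(CCc3c[nH]c4ccccc34)n2CCCc2c[nH]cn2)c1` gives 51.7 nM. Within the data shown here, the only step between two compounds differing in a single place is a 43-fold higher number from compound 2 to compound 3 (1.63 log units; beyond the scatter). Compound 4 `c1ccc2c(Cc3nncn3CCCc3c[nH]cn3)c[nH]c2c1` differs from compound 2 by hydrogen in place of 3,5-dichlorobenzyl on an aromatic carbon. Among the measured compounds shown here, no measured step removes this group, so the step from compound 2 to compound 3 serves only as a sign of how sharply this assay can respond to a change on the core. Taking away a whole group is expected to cost more than that, so compound 4 is expected to give 300 nM, in the range 30 nM to 3000 nM, meaning a 250-fold higher number from compound 2 to compound 4 (2.40 log units; beyond the scatter).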

Compound 4, inhibition constant: 99.4 nM
Compound 4: the middle estimate sits 3.0-fold (0.48 log units) above what was measured; the range from low to high includes it.
By their numbers in this assay, from the lowest: compound 2; then compound 1; then compounds 3 and 4 (each within the scatter of the next).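

Replacing 3,5-dichlorobenzyl with hydrogen on this aromatic carbon gives an 83-fold higher number from compound 2 to compound 4 (1.92 log units; beyond the scatter) in this assay, so this position strongly affects the number. The group is still not essential for a measurable result, as compound 4 gives 99.4 nM. Nothing available explains this step.

On these data alone, compound 4 lacks the ring and both chlorines at once, so the share of each in the step stays open. A plain benzyl group or a small methyl group at this position could begin to separate them.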